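Removing the Ring Substituents in a Diphenylmethylpiperidine Series

This account rests on a few compounds, and the source may have more. Where it says the series, first, only, none or still open, it means among the compounds named here.

Measured so far:
- compound 1, `COc1cc(C(C)=O)ccc1OCCCCCN1CCC(C(c2ccc(F)cc2)c2ccc(F)cc2)CC1`: 3.16 nM in a functional assay (aorta) with Oryctolagus cuniculus as the target; a lower number here means tighter binding, a higher number weaker binding
- compound 2, `COc1cc(C#N)ccc1OCCCN1CCC(C(c2ccc(F)cc2)c2ccc(F)cc2)CC1`: 2 nM in this assay

Of the compounds shown here, two have been measured. In this assay compound 1 gives 3.16 nM, and in this assay compound 2 gives 2 nM. Compound 2 has the lowest of the two numbers, but its nearest neighbour, compound 1, lies within the usual scatter, so the two cannot be told apart with confidence.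

Compound 3, `Fc1ccc(C(c2ccc(F)cc2)C2CCN(CCCOc3ccccc3)CC2)cc1`, has not yet been measured. It differs from compound 2 in one place: phenyl in place of 4-cyano-2-methoxyphenyl on an oxygen on a saturated carbon. Among the compounds with values here, both measured compounds carry a substituted aromatic ring on that oxygen, and no step between them shows what the bare phenyl does, so the direction of the change has to be guessed. The expectation is a small loss, a step in this assay that is expected to be no more than slightly beyond the scatter: a 3.0-fold higher number from compound 2 to compound 3 (0.48 log units; beyond the scatter). The estimated value for compound 3 in this assay is 6 nM, with a range from 2 nM to 20 nM.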

Compound 3, dissociation constant: 1.59 nM
Beside the measured number, compound 3's estimate is 3.8-fold (0.58 log units) above it; the whole stated range lies above it.
By their numbers in this assay, from the lowest: compounds 3, 2 and 1 (each within the scatter of the next).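

In this assay, the step from the substituted ring to the bare one is a 1.3-fold lower number from compound 2 to compound 3 (0.10 log units; within the scatter), so compound 2 and compound 3 cannot be told apart. Within the data shown here, this step removes the nitrile and the methoxy group together, taking the group on the oxygen from 10 heavy atoms and 2 hydrogen-bond acceptors to 6 heavy atoms and 0 hydrogen-bond acceptors, and the earlier compounds could not show that the number stays within the scatter without them. For this pair, then, a plain phenyl on the oxygen is enough to give a number that cannot be told apart from that of the substituted ring, though nothing available explains why the change makes so little difference.

Going by these compounds, the nitrile and the methoxy group leave in a single step, so what each does alone remains open, and a ring carrying only one of them would be needed to separate the two. Also open, on these data alone, is whether an amine or a carboxylic acid on that phenyl ring would move the number beyond the scatter in either direction.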